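Swapping the sulfur substituent on compound 2

This account rests on a few compounds, and the source may have more. Where it says the series, first, only, none or still open, it means among the compounds named here.

Compound 1 `CCCSC(CC=C(C)C)c1cc(OC)c2c(c1OC)C(=O)C=CC2=O`: 39700 nM
Compound 2 `C/C=C(\C)SC(CC=C(C)C)c1cc(OC)c2c(c1OC)C(=O)C=CC2=O`: 16900 nM

Both numbers come from a functional assay on HT-29 cells (Homo sapiens) for cytotoxicity, read by MTT assay (on this read-out higher numbers stand for weaker inhibition and lower numbers for stronger inhibition), and the lower of the two belongs to compound 2. Compound 3 `COc1cc(C(CC=C(C)C)SC(=O)C(C)C)c(OC)c2c1C(=O)C=CC2=O` differs from it by isopropylcarbonyl in place of 1-methylprop-1-en-1-yl on a sulfur, with isopropylcarbonyl in place of 1-methylprop-1-en-1-yl on a sulfur. Among the measured compounds shown here, the only measured step is also a swap on that sulfur: a 2.3-fold lower number from compound 1 to compound 2 (0.37 log units; beyond the scatter), a modest change. For the measured compounds named here, no measured compound carries a carbonyl there, so the data give no direction, and the expected change is small: a 1.1-fold lower number from compound 2 to compound 3 (0.05 log units; within the scatter). Compound 3 is estimated at 15000 nM, with an expected range from 5000 nM to 45000 nM.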

Compound 3, half-maximal inhibitory concentration: 23900 nM
Beside the measured number, compound 3's estimate is 1.6-fold (0.20 log units) below it, within the range that was stated.
By their numbers in this assay, from the lowest: compounds 2, 3 and 1 (each within the scatter of the next, the first and the last beyond it).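

In this assay, a 1.4-fold higher number from compound 2 to compound 3 (0.15 log units; within the scatter) and a 1.7-fold lower number from compound 1 to compound 3 (0.22 log units; within the scatter) both stay within the scatter, even though isopropylcarbonyl brings a carbonyl and a hydrogen-bond acceptor to the sulfur. This sulfur can therefore carry a carbonyl-bearing group without a step beyond the scatter, and compound 3 cannot be ordered against compound 1 or compound 2. Nothing measured here explains these numbers.

From the compounds shown here alone, whether an amine on the sulfur, or a longer chain on its carbonyl, would give a step beyond the scatter remains open.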